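The compounds below may be only part of what the source reports. "The series", "measured", "known", "first", "only" and "open" are said of these compounds alone.

Of the compounds shown here, three sharing one core have been tested in an ADME assay on HeLa cells (Homo sapiens) for cytotoxicity, with a stated time of 72 h; on this read-out lower numbers stand for higher toxicity in this test and higher numbers for lower toxicity in this test. Compound 2 (`COC(=O)C1CN(c2nc(=O)c3cc(C(F)(F)F)cc([N+](=O)[O-])c3s2)CCC12OC[C@H](C)O2`) gives 36000 nM. Compound 3 (`CN(c1nc(=O)c2cc(C(F)(F)F)cc([N+](=O)[O-])c2s1)[C@H]1CCN(Cc2ccccc2)C1`) gives 38000 nM, and these two numbers lie within the usual scatter of repeated measurements, so they cannot be told apart. Compound 1 (`COC(=O)[C@@H]1OC2(CCN(c3nc(=O)c4cc(C(F)(F)F)cc([N+](=O)[O-])c4s3)CC2)O[C@H]1c1ccccc1`) gives > 50000 nM, which is a limit of the assay and not a number. Compound 2 therefore shares its place on the scale with compound 3, and no measured number in this small set stands clearly apart from it.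

The next compound, compound 4 (`C[C@H]1COC2(CCN(c3nc(=O)c4cc(C(F)(F)F)cc([N+](=O)[O-])c4s3)CC2)O1`), is a simpler relative of compound 2. It has hydrogen in place of methoxycarbonyl on a saturated ring carbon. Among the measured compounds shown here, no pair of measured compounds differs in just one place, so no direct precedent exists for this change. The expectation rests on the overall spread of values: compound 3 carries no methoxycarbonyl and gives 38000 nM. The expected change is a 1.1-fold higher number from compound 2 to compound 4 (0.02 log units; within the scatter), which would be no step beyond the scatter, and a result at the limit of this assay would also not be surprising. For compound 4 the estimated value is 38000 nM, with an expected range from 17000 nM to 50000 nM.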

Compound 4, half-maximal cytotoxic concentration: > 50000 nM
Compound 4: a limit, no number; the forecaster's own chance of this, stated with the estimate: 35%; at least 1.3-fold (0.11 log units) between middle value and limit.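

Among the compounds shown here, this is the first comparison in the set between two compounds that differ in one place: in this assay, hydrogen in place of methoxycarbonyl on a saturated ring carbon gives an at least 1.3-fold higher number from compound 2 to compound 4 (0.14 log units; that floor lies within the scatter). The value of compound 4 is a limit of the assay and not a number, so this pair shows a direction with only a minimum size, and that minimum does not by itself separate compound 4 from compound 2. What can be said of this position is that losing the methoxycarbonyl brings no move towards higher toxicity in this test, while the true size of the step stays hidden because the read-out stops at this limit: the limit of > 50000 nM in this assay, at which 2 of the 4 values shown sit.

Still open, going by these compounds, is whether another group on this ring carbon, such as an amine, a carboxylic acid or a longer chain, would give a number clearly apart from that of compound 2. Also open, on these data alone, is whether the same swap of methoxycarbonyl for hydrogen would behave in the same way on the other compounds that share this core.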